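The compounds below may be only part of what the source reports. "The series", "measured", "known", "first", "only" and "open" are said of these compounds alone.

Values in a functional assay on HCT-116 cells (Homo sapiens) for cytotoxicity, read by MTT assay, with a stated time of 72 h; a higher number here means a weaker inhibitor, a lower number a stronger inhibitor:
compound 1 `COc1ccc(Nc2nc3ccccc3nc2S(=O)(=O)c2ccc(OC)cc2)cc1`: 29100 nM
compound 2 `COc1ccc(S(=O)(=O)c2nc3ccccc3nc2Nc2ccc(N)cc2)cc1`: 6300 nM
compound 3 `COc1ccc(S(=O)(=O)c2nc3ccccc3nc2Nc2cccc(N)c2)cc1`: 3710 nM

Two measured steps place compound 2 among these numbers: a 4.6-fold lower number from compound 1 to compound 2 (0.66 log units; beyond the scatter), and a 1.7-fold lower number from compound 2 to compound 3 (0.23 log units; within the scatter). Compound 4 `Nc1ccc(Nc2nc3ccccc3nc2S(=O)(=O)c2ccc(Br)cc2)cc1` differs from compound 2 at one place, on an aromatic carbon of a six-membered aromatic ring of carbon only, with bromo in place of methoxy on an aromatic carbon. Among the measured compounds shown here, no measured step touches this methoxy. The nearest guide replaced a different methoxy and was modest in size: a 4.6-fold lower number from compound 1 to compound 2 (0.66 log units; beyond the scatter). Only a small shift in this assay is therefore expected, with its direction open, and the estimated change is a 1.3-fold lower number from compound 2 to compound 4 (0.10 log units; within the scatter). For compound 4 the expected value is 5000 nM, with an estimated range from 1500 nM to 17000 nM.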

Compound 4, half-maximal inhibitory concentration: 1390 nM
The estimate for compound 4 lay 3.6-fold (0.56 log units) above the measured number; measured number below the stated range.
By their numbers in this assay, from the lowest: compound 4; then compounds 3 and 2 (each within the scatter of the next); then compound 1.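

In this assay, among the compounds shown here, this methoxy turns out not to be a silent spot: bromo in its place gives a 4.5-fold lower number from compound 2 to compound 4 (0.66 log units; beyond the scatter) and so the earlier compounds' untouched 4-methoxyphenyl group can clearly move the number. The change also removes a hydrogen-bond acceptor and one heavy atom, but nothing measured here says what lies behind the shift.

Going by these compounds, it remains open whether chloro, fluoro or methyl at this place would give a similar step. On these data alone, it is also open whether bromo would do the same alongside the 3-aminophenyl group of compound 3.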